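Indoline thiocarbamate benzamides: nitro on the fused ring

The source may hold more compounds than are shown below. What is called first, only, known or untested is meant among the compounds shown, and "the series" means these compounds.

Measured in a functional assay on HeLa cells (Homo sapiens) for antiproliferative activity, read by CCK-8 assay, with a stated time of 72 h, tested at 8 uM; a higher number here means a stronger effect of the compound at the concentration tested, a lower number a weaker effect:
compound 1 `Nc1ccccc1NC(=O)c1ccc(CSC(=S)N2CCc3ccccc32)cc1` — 67%
compound 2 `CN(Cc1ccncc1)C(=S)SCc1ccc(C(=O)Nc2ccccc2N)cc1` — 72.7%
compound 3 `Nc1ccccc1NC(=O)c1ccc(CSC(=S)N2CCCC2)cc1` — 77.8%

The three compounds share a core and differ only in the amine on the thiocarbonyl carbon. Compound 1 stands at the low end of the three numbers: from compound 1 to compound 2 the step is a number 5.7 percentage points higher from compound 1 to compound 2 (within the scatter), and from compound 1 to compound 3 it is a number 10.8 percentage points higher from compound 1 to compound 3 (beyond the scatter), the only one of the three that clears the scatter. Between compound 2 and compound 3 the step is a number 5.1 percentage points higher from compound 2 to compound 3 (within the scatter).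

Compound 4 `Nc1ccccc1NC(=O)c1ccc(CSC(=S)N2CCc3cc([N+](=O)[O-])ccc32)cc1` is not yet measured. It keeps the amine of compound 1 and changes it by nitro in place of hydrogen on an aromatic carbon. Among the compounds with values here, none of the measured steps bears directly on this change: each of them swaps the whole amine, none alters a substituent on the 2,3-dihydro-1H-indol-1-yl ring. The measured steps are small in any case, spanning from within the scatter to a modest gain, so they give no ground to expect a large move in either direction.

Compound 4 is therefore expected to stay close to compound 1 in this assay, with a step of no change at the digits printed from compound 1 to compound 4 (within the scatter). The estimate for compound 4 is 67%, with a range from 50% to 82%.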

Compound 4, a percentage reported as inhibition, at one concentration (the size of the read-out at that concentration, not a potency): 43.6%
The estimate for compound 4 lay 23.4 percentage points above the measured number, and the stated range ends above it.
By their numbers in this assay, from the lowest: compound 4; then compounds 1, 2 and 3 (each within the scatter of the next, the first and the last beyond it).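

In this assay, the aromatic ring of the 2,3-dihydro-1H-indol-1-yl amine proves to be a sensitive place in the series: nitro in place of hydrogen gives a number 23.4 percentage points lower from compound 1 to compound 4 (beyond the scatter), a larger step than any of the whole-amine swaps among compounds 1, 2 and 3. The earlier compounds shown here showed only what exchanging the entire amine does, whereas this change keeps the amine and adds just one group of 3 heavy atoms, with no ring, on an aromatic carbon that is meta to a fused ring and para to a fused ring. Nothing at hand accounts for the loss, so the result stands as an observation at a single concentration, for a single group at a single place, without an assigned reason.

Going by these compounds, whether the loss belongs to nitro itself or would follow any group on this carbon stays open, and an amine, a methoxy group or a fluorine at the same place on compound 1 would separate those readings. Also open is how the other aromatic carbons of this ring respond, since the compounds shown carry a substituent at this one place only.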